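A few compounds are considered here, and "the series" means these few. Any claim that something is new, unique, unknown or untested is made for them only; others in the source may bear on it.

Measured compounds:
compound 1 `COc1cc2c(cc1OC)C(CC(N)=O)CC2`: 18.8%
compound 2 `CNC(=O)CC1CCc2cc(OC)c(OC)cc21`: 15.6%
compound 3 `COc1cc2c(cc1OC)C(CC(=O)NC(C)C)CC2`: 31.3%

All three compounds share one core and differ only in the group carried on the amide-type nitrogen. In a functional assay on the whole organism (strain Wistar) for inhibition, with Rattus norvegicus as the target, read by paw edema, with stated times of 60 min and 1 h, at a dose of 100 mg/kg by the oral route (on this read-out higher numbers stand for more inhibition at the one dose given (going by the name of the read-out) and lower numbers for less inhibition), compound 3 stands highest of the three: the step of a number 12.5 percentage points higher from compound 1 to compound 3 (beyond the scatter) and the step of a number 15.7 percentage points higher from compound 2 to compound 3 (beyond the scatter) both lie beyond the scatter, whereas the step of a number 3.2 percentage points lower from compound 1 to compound 2 (within the scatter) does not, so compound 1 and compound 2 cannot be ranked against each other.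

Compound 4 `COc1cc2c(cc1OC)C(CC(=O)NC(C)(C)C)CC2` is the next member of this short series. It differs from compound 3 by methyl in place of hydrogen on a saturated chain carbon bound to an amide-type nitrogen and two saturated chain carbons. The two steps that bear on this change are those in which the nitrogen substituent grew: from hydrogen to isopropyl and from methyl to isopropyl, each giving a modest rise in this assay. Among the compounds with values here, the change to compound 4 is smaller, a single carbon added to a group that is already branched, and only two steps of that kind are known. A small rise, or no step beyond the scatter, is therefore expected: the estimated step is a number 3.7 percentage points higher from compound 3 to compound 4 (within the scatter). Compound 4 is expected to reach about 35% in this assay, with a likely range from 20% to 50%.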

Compound 4, a percentage reported as inhibition, in the whole organism at one dose (the size of the read-out at that dose, not a potency): 31.3%
Compound 4: the middle estimate sits 3.7 percentage points above what was measured; measured number inside the range.
By their numbers in this assay, from the lowest: compounds 2 and 1 (each within the scatter of the next); then compounds 3 and 4 (each within the scatter of the next).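

In this assay, the extra methyl that turns isopropyl into tert-butyl gives no change at the digits printed from compound 3 to compound 4 (within the scatter), so the rise seen when hydrogen or methyl on the nitrogen gave way to isopropyl does not visibly continue at this saturated chain carbon. The tert-butyl group still keeps the gain over the smaller nitrogen substituents, with a number 15.7 percentage points higher from compound 2 to compound 4 (beyond the scatter) and a number 12.5 percentage points higher from compound 1 to compound 4 (beyond the scatter), so the four compounds now fall into two groups: compound 1 and compound 2 in the lower one, compound 3 and compound 4 in the upper one. No information on hand offers a reason why the isopropyl and tert-butyl amides cannot be told apart here.

The compounds shown leave open whether this upper level holds for other groups on the nitrogen, such as a longer chain like n-butyl, a cyclohexyl or phenyl ring, or a chain carrying an amine or a carboxylic acid. The numbers shown also come from a single dose, so whether compound 3 and compound 4 would still stand together at other doses remains an open question.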